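A methyl step from compound 2

The source may report more compounds than this note shows. Statements on the series, on what has been measured and on what is new or still open speak of the compounds shown alone.

In a physicochemical assay for solubility (a higher number here means a more soluble compound, a lower number a less soluble compound), compound 1 (`Cc1cc(N2CCc3nnn(Cc4ccc5ncccc5c4)c3C2=O)sn1`) gives 43.2 ug/mL and compound 2 (`Cc1cc(-n2ccc3nnn(Cc4ccc5ncccc5c4)c3c2=O)sn1`) gives 80.1 ug/mL, two values within the scatter of each other. Compound 3 (`Cc1cc(-n2ccc3nnn([C@@H](C)c4ccc5ncccc5c4)c3c2=O)sn1`) has methyl in place of hydrogen on a saturated chain carbon bound to an aromatic carbon and an aromatic nitrogen. For the measured compounds named here, no measured pair shows this change, so the expectation is weakly founded: no step beyond the scatter, in either direction. The estimated step, a 1.1-fold lower number from compound 2 to compound 3 (0.06 log units; within the scatter), stays within that scatter. For compound 3 the expected value is 70 ug/mL, with an estimated range of 30 ug/mL to 160 ug/mL.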

Compound 3, solubility: >= 200 ug/mL
Compound 3: only a limit was reported; the forecaster's own chance of this, stated with the estimate: 3%; middle value at least 2.8-fold (0.45 log units) from the limit.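

In this assay, for the compounds shown here, methyl in place of hydrogen on a saturated chain carbon bound to an aromatic carbon and an aromatic nitrogen gives an at least 2.4-fold higher number from compound 2 to compound 3 (0.39 log units; beyond the scatter), the only one-place step so far and one beyond the scatter. This carbon is therefore a position where a single added carbon moves the read-out upward. Compound 3 gives a limit of the assay, so the full size of the step stays unknown: the limit of >= 200 ug/mL in this assay, at which 1 of the 3 values shown sits.

On these data alone, whether an ethyl group, a longer chain or an amine at this carbon moves the number the same way remains open. So does the effect of the opposite arrangement of the methyl at this carbon.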